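The source may hold more compounds than are shown below. What is called first, only, known or untested is meant among the compounds shown, and "the series" means these compounds.

Compound 1, `COC(=O)[C@@]1(C)CCC=C2[C@@H]1CC[C@@H](C)[C@]2(C)Cc1c[nH]c2c(Cl)cccc12`, is measured in a functional assay on SW1573 cells (Homo sapiens) for inhibition, read by sulforhodamine B assay, with a stated time of 48 h (on this read-out higher numbers stand for weaker inhibition of growth and lower numbers for stronger inhibition of growth), where compound 1 gives 14000 nM. Compound 2, `COC(=O)[C@@]1(C)CCC=C2[C@@H]1CC[C@@H](C)[C@]2(C)Cc1c(C)[nH]c2c(Cl)cccc12`, differs from compound 1 by methyl in place of hydrogen on an aromatic carbon, and in this assay compound 2 gives 19000 nM, a step of a 1.4-fold higher number from compound 1 to compound 2 (0.13 log units; within the scatter). Compound 3, `COC(=O)[C@@]1(C)CC[C@@H]2C3=C1CC[C@@H](C)[C@]3(C)Cc1c2[nH]c2ccccc12`, rests on a different core, and the difference between the two cores is not broken down here; in this assay compound 3 gives 8300 nM, which lies within the scatter of compound 1 and beyond it against compound 2.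

Compound 4, `COC(=O)[C@@]1(C)CC[C@@H]2C3=C1CC[C@@H](C)[C@]3(C)Cc1c2[nH]c2ccc(C)cc12`, has not yet been measured. It differs from compound 3 by methyl in place of hydrogen on an aromatic carbon, the same kind of change as that from compound 1 to compound 2, but here the methyl sits on a six-membered aromatic ring of carbon only, meta to a fused ring and para to a fused ring, rather than on the five-membered aromatic ring with one nitrogen, next to the ring nitrogen. Because the earlier change gave a 1.4-fold higher number from compound 1 to compound 2 (0.13 log units; within the scatter), a step of about a 1.2-fold higher number from compound 3 to compound 4 (0.08 log units; within the scatter) is expected in this assay for compound 4. Compound 4 is therefore estimated at 10000 nM, expected to fall between 4000 nM and 25000 nM.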

Compound 4, concentration for 50% growth inhibition: 15000 nM
Beside the measured number, compound 4's estimate is 1.5-fold (0.18 log units) below it, and the stated range covers the measured number.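

In this assay, methyl in place of hydrogen on an aromatic carbon of a six-membered aromatic ring of carbon only gives a 1.8-fold higher number from compound 3 to compound 4 (0.26 log units; within the scatter). Set beside the earlier step on the other core, the change carries over without a difference that can be told from the scatter: the same change on two cores in this assay, a 1.4-fold higher number (0.13 log units; within the scatter) from compound 1 to compound 2 and a 1.8-fold higher number (0.26 log units; within the scatter) from compound 3 to compound 4, 1.3-fold (0.12 log units) apart, within the scatter of two such steps. This does not show that the change acts alike on both cores, as the methyl sits on a six-membered aromatic ring of carbon only in one pair and on a five-membered aromatic ring with one nitrogen in the other, each core offers a single pair, and neither step by itself stands beyond the scatter.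

The compounds shown leave open whether a group other than methyl, such as an ethyl chain, a methoxy group or an amine, would give a step that stands beyond the scatter on either core. They also leave open how either core would read with a carboxylic acid in place of the methyl ester.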